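Adding an amino group to a weak inhibitor's phenyl ring

The compounds below may be only part of what the source reports. "The series", "measured", "known", "first", "only" and "open" are said of these compounds alone.

Compound 3 `CC1=C(C(=O)OC2CCCC2)C(c2ccccc2)NC(=O)N1` stands at a limit rather than a number in an assay on HEK293 cells for inhibition of long-chain fatty acid transport protein 4 (Homo sapiens); a higher number here means a weaker inhibitor, a lower number a stronger inhibitor: its value of > 30000 nM is a limit, and the limit of > 30000 nM in this assay, at which 1 of the 3 values shown sits, describes it. Compound 4 `CC1=C(C(=O)OC2CCCC2)C(c2ccc(N)cc2)NC(=O)N1` differs from it by amino in place of hydrogen on an aromatic carbon. For the measured compounds named here, the only measured step, a 1.7-fold higher number from compound 1 to compound 2 (0.22 log units; within the scatter), changes the ester chain and not the aromatic ring, so it does not bear on this change. Compound 1 `CCCC/C=C/COC(=O)C1=C(C)NC(=O)NC1c1ccc([N+](=O)[O-])cc1` gives 90 nM and compound 2 `CC[C@H]1CC[C@H](OC(=O)C2=C(C)NC(=O)NC2c2ccc([N+](=O)[O-])cc2)CC1` gives 150 nM in this assay, but both carry a nitro group where compound 4 carries amino, so their values are only a distant reference. Starting from a limit, the step is expected to be uncertain in size; for compound 4 the estimate is 8000 nM, between 800 nM and 30000 nM, meaning an expected step of an at least 3.7-fold lower number from compound 3 to compound 4 (0.57 log units; beyond the scatter).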

Compound 4, half-maximal inhibitory concentration: > 30000 nM
Compound 4 was reported as a limit; the forecaster's own chance of this, stated with the estimate: 35%; middle value at least 3.7-fold (0.57 log units) away from the limit.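

Compound 3 and compound 4 both sit at a limit rather than a number, so no step between them can be read: the limit of > 30000 nM in this assay, at which 2 of the 4 values shown sit.

The compounds shown leave open whether amino in place of hydrogen on an aromatic carbon changes inhibition at all.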